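Adding Fluorine to the Most Potent of Three Agonists

This account rests on a few compounds, and the source may have more. Where it says the series, first, only, none or still open, it means among the compounds named here.

Measured in a functional assay for agonist activity at Glucose-dependent insulinotropic receptor (Homo sapiens); on this read-out lower numbers stand for an effect already at smaller amounts and higher numbers for an effect only at larger amounts of compound:
Compound 1 `Cc1noc(C2CCN(c3ncnc(Nc4ccc(S(C)(=O)=O)cc4)c3[N+](=O)[O-])CC2)n1` gives 260 nM
Compound 2 `CS(=O)(=O)c1ccc(Nc2ncnc(N3CCC(c4nc(-c5cccnc5)no4)CC3)c2[N+](=O)[O-])cc1` gives 660 nM
Compound 3 `CCS(=O)(=O)c1ccc(Nc2ncnc(N3CCC(c4nc(C(C)C)no4)CC3)c2[N+](=O)[O-])cc1` gives 17 nM

Compound 3 stands lowest of the three numbers, and its gaps to compound 1 and to compound 2 both lie beyond the usual scatter, so it is the most potent compound here. Compound 4 `CCS(=O)(=O)c1ccc(Nc2ncnc(N3CCC(c4nc(C(C)C)no4)CC3)c2[N+](=O)[O-])c(F)c1` differs from compound 3 by fluoro in place of hydrogen on an aromatic carbon. For the measured compounds named here, the only measured step, a 2.5-fold higher number from compound 1 to compound 2 (0.40 log units; beyond the scatter), concerns a different part of the shared core and so gives no guide to this change. With nothing measured that bears on a fluorine at this place, a step within the scatter is expected in this assay, namely no change at the digits printed from compound 3 to compound 4 (within the scatter). Compound 4 is therefore estimated at 17 nM, between 6 nM and 50 nM.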

Compound 4, half-maximal effective concentration: 7 nM
Estimate against measurement, compound 4: 2.4-fold (0.39 log units) above; the range from low to high includes it.
By their numbers in this assay, from the lowest: compound 4; then compound 3; then compound 1; then compound 2.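

In this assay, for the compounds shown here, the step of a 2.4-fold lower number from compound 3 to compound 4 (0.39 log units; beyond the scatter) is modest but beyond the scatter, and it is the first measured change on this ring, where compounds 1 to 3 all carry hydrogen. It shows that this place, ortho to a large group and meta to an ethylsulfonyl group, accepts a fluoro without loss of potency and with a small gain. No measurement available here accounts for the gain.

Going by these compounds, whether a chloro, methyl or methoxy group at this place would give a lower or higher number remains open. So does whether fluoro would give a similar step in compound 1 or compound 2.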